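A few compounds are considered here, and "the series" means these few. Any claim that something is new, unique, unknown or untested is made for them only; others in the source may bear on it.

Compound 2 `NS(=O)(=O)CC(=O)NCCSc1nonc1/C(=N/O)Nc1ccc(F)c(Br)c1` is one of two compounds assessed in an ADME assay on isolated protein for pharmacokinetics, with UDP-glucuronosyltransferase 1A9 (Homo sapiens) as the target, read by LC-MS, with a stated time of 60 min, at 37 degrees C, tested at 1 uM, in the presence of a further agent that is not named here; a higher number here means that the compound lasts longer, a lower number that the compound disappears faster. In this assay compound 2 gives 0.758 h, the only result reported as a number. Compound 1 `NS(=O)(=O)CC(=O)NCCSc1nonc1/C(=N/O)Nc1cccc(C(F)F)c1` differs from compound 2 only on the amine nitrogen. In this assay compound 1 gives > 3 h, a value reported as a limit of the assay and not as a number. Going by the values given here, the step of an at least 3.9-fold lower number from compound 1 to compound 2 (0.59 log units; beyond the scatter) is the only measured comparison, and it rests on (the limit of > 3 h in this assay, at which 1 of the 2 values shown sits), so its true size is not fixed. Compound 3 `CS(=N)(=O)CC(=O)NCCSc1nonc1/C(=N/O)Nc1ccc(F)c(Br)c1` has not yet been measured. Among the compounds with values here, it differs from compound 2 by a group of 4 heavy atoms (1 carbon, 1 nitrogen, 1 oxygen, 1 sulfur; no ring) in place of a group of 4 heavy atoms (1 nitrogen, 2 oxygen, 1 sulfur; no ring), on a saturated chain carbon bound to a carbonyl carbon, a change on the chain rather than on the amine nitrogen, where the single measured step lies. That step therefore does not bear directly on the change from compound 2 to compound 3, and no comparison among the compounds shown tests a change of this kind. The expectation is therefore for no step beyond the scatter, expressed as a 1.0-fold higher number from compound 2 to compound 3 (0.00 log units; within the scatter). Compound 3 is estimated to give 0.76 h in this assay, with a range from 0.3 h to 2 h.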

Compound 3, half-life: 1.53 h
Compound 3: middle estimate off by 2.0-fold (0.30 log units), on the low side; the measured number falls inside the stated range.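

The chain position, on a saturated chain carbon bound to a carbonyl carbon, now has a measured step of its own in this assay: a 2.0-fold higher number from compound 2 to compound 3 (0.31 log units; beyond the scatter). The half-life therefore responds to a change at this place as well as to the earlier change on the amine nitrogen. The entering group matches sulfamoyl in its heavy atom count, double bonds outside aromatic rings, hydrogen-bond donors and hydrogen-bond acceptors, yet the swap still moves the number beyond the scatter, and nothing measured here accounts for that shift.

The compounds shown do not tell whether this change would have the same effect with 3-(difluoromethyl)phenyl on the amine nitrogen, and the true size of the step on that nitrogen remains unfixed: the limit of > 3 h in this assay, at which 1 of the 3 values shown sits. They also leave open how a methyl sulfone, a carboxylic acid, a primary amide or a longer chain at this place would compare with sulfamoyl and with the group that replaced it.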